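Swapping a carbonyl for a sulfonyl on a shared core

A few compounds are considered here, and "the series" means these few. Any claim that something is new, unique, unknown or untested is made for them only; others in the source may bear on it.

The series rests on the core shown in compound 2 `O=C(NCCNc1nccc(-c2c(-c3cccc(F)c3)nc3sccn23)n1)c1ccc(Cl)cc1`, which in a functional assay on A-375 cells (Homo sapiens) for cytotoxicity, read by MTT assay (a lower number here means a stronger inhibitor, a higher number a weaker inhibitor), gives 2570 nM, the lowest of the three numbers. Compound 1 `O=C(NCCCNc1nccc(-c2c(-c3cccc(F)c3)nc3sccn23)n1)c1ccc(F)cc1` gives 14900 nM, and a 5.8-fold lower number from compound 1 to compound 2 (0.76 log units; beyond the scatter). Compound 3 `O=S(=O)(NCCNc1nccc(-c2c(-c3cccc(F)c3)nc3sccn23)n1)c1ccc(C(F)(F)F)cc1` gives 7440 nM. Compound 4 `O=S(=O)(NCCNc1nccc(-c2c(-c3cccc(F)c3)nc3sccn23)n1)c1ccc(Br)cc1` carries (4-bromophenyl)sulfonyl in place of (4-chlorophenyl)carbonyl on an amine nitrogen. Within the data shown here, no single step covers this change. Compound 3, the only other sulfonyl, gives 7440 nM against compound 2 at 2570 nM, but it also bears a different ring substituent, so the two values do not isolate the sulfonyl. A weakening step is therefore expected, a 2.1-fold higher number from compound 2 to compound 4 (0.33 log units; beyond the scatter), modest and somewhat uncertain. Compound 4 is estimated at 5500 nM, within 2000 nM to 15000 nM.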

Compound 4, half-maximal inhibitory concentration: 13500 nM
Compound 4: the middle estimate sits 2.5-fold (0.39 log units) below what was measured; measured number inside the range.
By their numbers in this assay, from the lowest: compound 2; then compounds 3, 4 and 1 (each within the scatter of the next).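

The step from the carbonyl to the sulfonyl on this amine nitrogen is a clear loss, a 5.3-fold higher number from compound 2 to compound 4 (0.72 log units; beyond the scatter), larger than the gap between compound 2 and compound 3 alone suggested. By contrast, bromo in place of trifluoromethyl on an aromatic carbon gives only a 1.8-fold higher number from compound 3 to compound 4 (0.26 log units; within the scatter), and the step from the remaining amide gives a 1.1-fold lower number from compound 1 to compound 4 (0.04 log units; within the scatter). No evidence here accounts for the loss.

The change from compound 2 to compound 4 swaps the linker and the halogen together, so their shares remain unseparated. A (4-chlorophenyl)sulfonyl group would divide them.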